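Phenoxy to 4-bromophenyl: what compound 3 may tolerate

The compounds below may be only part of what the source reports. "The series", "measured", "known", "first", "only" and "open" are said of these compounds alone.

Measured so far in an ADME assay on Huh-7 cells (Homo sapiens) for cytotoxicity; a higher number here means that more compound is tolerated, a lower number that less compound is tolerated:
Compound 1 `O=C(NC(=S)N1CCc2c(OCc3ccccc3)cccc21)c1ccccc1` gives > 50000 nM, a limit of the assay rather than a number.
Compound 2 `O=C(NC(=S)N1CCc2c(OCCCCCOc3ccc(Cl)cc3)cccc21)Oc1ccccc1` gives > 50000 nM, likewise a limit.

Compound 2 thus stands at the limit of > 50000 nM in this assay, at which 2 of the 2 values shown sit, so the two results cannot be told apart. Compound 3 `O=C(NC(=S)N1CCc2c(OCCCCCOc3ccc(Cl)cc3)cccc21)c1ccc(Br)cc1` differs from compound 2 by 4-bromophenyl in place of phenoxy on a carbonyl carbon. With both measured values sitting at the limit, the step of a number no higher from compound 2 to compound 3 (the limit leaves the size open) is expected to be none beyond the scatter. Compound 3 is estimated at 50000 nM, within a range from 20000 nM to 100000 nM, and will most likely again be reported only as a limit.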

Compound 3, half-maximal cytotoxic concentration: 29100 nM
For compound 3 the middle estimate is 1.7-fold (0.24 log units) above the measured one, and the stated range covers the measured number.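

In this assay, compound 3 shows that a group on this carbonyl carbon can give a true number, whereas the earlier results were only limits: the limit of > 50000 nM in this assay, at which 2 of the 3 values shown sit. Placing 4-bromophenyl in place of phenoxy gives an at least 1.7-fold lower number from compound 2 to compound 3 (0.23 log units; that floor lies within the scatter), so a real drop with this change is possible but not established. Left open is how far compound 2 truly lies from compound 3, and whether an amine or a carboxylic acid on that carbonyl carbon would move the number further.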